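This account rests on a few compounds, and the source may have more. Where it says the series, first, only, none or still open, it means among the compounds named here.

Measured compounds in a functional assay on DU-145 cells (Homo sapiens) for antiproliferative activity, read by propidium iodide staining, with a stated time of 96 h; a higher number here means a weaker inhibitor, a lower number a stronger inhibitor:

compound 1 `CC(O)(CSc1ccc(S(F)(F)(F)(F)F)cc1)C(=O)Nc1ccc(C#N)cc1C(F)(F)F`, giving 17700 nM
compound 2 `CC(O)(CSc1ccc(S(F)(F)(F)(F)F)cc1)C(=O)Nc1ccc([N+](=O)[O-])cc1C(F)(F)F`, giving 14500 nM
compound 3 `CC(O)(COc1ccc(S(F)(F)(F)(F)F)cc1)C(=O)Nc1ccc(C#N)c(C(F)(F)F)c1`, giving 25500 nM

Compound 4 `CC(O)(COc1ccc(S(F)(F)(F)(F)F)cc1)C(=O)Nc1ccc([N+](=O)[O-])c(C(F)(F)F)c1` is not yet measured in this assay.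

The difference between the core of compound 1 and the core of compound 3 is not broken down here. The step from compound 1 to compound 2 is nitro in place of cyano on an aromatic carbon; the step from compound 3 to compound 4 is nitro in place of cyano on an aromatic carbon. The two are the same kind of change, not the same: in the first the place is meta to a trifluoromethyl group, in the second it is ortho to a trifluoromethyl group. In this assay the first gave a 1.2-fold lower number from compound 1 to compound 2 (0.09 log units; within the scatter).

For compound 4 the expected step is a 1.2-fold lower number from compound 3 to compound 4 (0.08 log units; within the scatter), resting on the measured step of a 1.2-fold lower number from compound 1 to compound 2 (0.09 log units; within the scatter). Compound 4 is therefore estimated at 21000 nM, with a range from 10000 nM to 45000 nM.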

Compound 4, half-maximal inhibitory concentration: 21200 nM
Beside the measured number, compound 4's estimate is 1.0-fold (0.00 log units) below it; low and high end bracket the measured number.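

In this assay, nitro in place of cyano gives a 1.2-fold lower number from compound 3 to compound 4 (0.08 log units; within the scatter), and the step on the second core matches the earlier one: the same change on two cores in this assay, a 1.2-fold lower number (0.09 log units; within the scatter) from compound 1 to compound 2 and a 1.2-fold lower number (0.08 log units; within the scatter) from compound 3 to compound 4, 1.0-fold (0.01 log units) apart, within the scatter of two such steps. This shows that the change stays within the scatter on both cores, including where the place is ortho to a trifluoromethyl group. It does not show that a measurable effect carries over, since neither step stands out from the scatter, and two cores give a narrow basis, with the difference between them not broken down.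

The compounds shown carry only cyano or nitro at this place, so the reading with an amine or a carboxylic acid there remains open.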